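Replacing the Methyl on the Carbonyl of Compound 2

A few compounds are considered here, and "the series" means these few. Any claim that something is new, unique, unknown or untested is made for them only; others in the source may bear on it.

Among the measured compounds shown here, only two compounds frame this step. In a functional assay on T98G cells (Homo sapiens) for inhibition, read by MTT assay, with a stated time of 72 h (on this read-out higher numbers stand for weaker inhibition and lower numbers for stronger inhibition), compound 1 `CC1(C)CC(NC(=O)Nc2ccccc2)c2cc(Cl)ccc2O1` gives 34000 nM. Compound 2 `CC(=O)NC1CC(C)(C)Oc2ccc(Cl)cc21` has no single number on this scale, as its result reads "not determined" (no result reported), so it offers no starting point. Compound 3 `CC1(C)CC(NC(=O)Nc2cccc(Cl)c2)c2cc(Cl)ccc2O1` differs from compound 2 in one place. It carries (3-chlorophenyl)amino in place of methyl on a carbonyl carbon. For the measured compounds named here, without a number for compound 2, the step itself cannot be sized, and no step between measured compounds serves as a guide. Going by the values given here, the one available anchor is compound 1, at 34000 nM, which shares its core with compound 3. A difference from that value no larger than the usual scatter of this assay is therefore expected, in either direction. For compound 3, the estimated value is 26000 nM, with an expected range from 11000 nM to 60000 nM.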

Compound 3, half-maximal inhibitory concentration: 25000 nM
Compound 3: the middle estimate sits 1.0-fold (0.02 log units) above what was measured, within the range that was stated.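

In this assay, adding chloro in place of hydrogen on an aromatic carbon gives a 1.4-fold lower number from compound 1 to compound 3 (0.13 log units; within the scatter), so this single change to the phenyl leaves the read-out where the scatter cannot separate the two compounds. Compound 3 also supplies a number for a compound carrying (3-chlorophenyl)amino on the carbonyl carbon, yet the step from methyl to that group cannot be read, since compound 2 has no single number. No supporting data offer an explanation for this result.

As far as these compounds go, whether a carboxylic acid or a methoxy group in place of that chloro would move the number beyond the scatter remains open. So does how cyclohexylamino on the same carbonyl carbon would compare with (3-chlorophenyl)amino.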